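A few compounds are considered here, and "the series" means these few. Any claim that something is new, unique, unknown or untested is made for them only; others in the source may bear on it.

In a toxicity assay on the whole organism (strain Icem-CET (SPF Caw)) for cytotoxicity, with Mus musculus as the target (on this read-out lower numbers stand for an effect already at smaller amounts and higher numbers for an effect only at larger amounts of compound), compound 2, whose structure is `C#CCNC(=O)/C(C)=C(\C)c1ccc(Br)cc1`, gives 150 mg/kg. That is the lowest of the three numbers at hand: compound 1, `COc1ccc(/C(C)=C(/C)C(=O)NC2CC2)cc1`, gives 300 mg/kg, which is within the usual scatter of compound 2, while compound 3, `C=CCNC(=O)/C(C)=C(/C)c1ccc(Cl)cc1`, gives 400 mg/kg, a gap that goes beyond the scatter. Compound 4, `C=CCNC(=O)/C(C)=C(\C)c1ccc(Br)cc1`, has not yet been measured in this assay; it differs from compound 2 by vinyl in place of ethynyl on a saturated chain carbon bound to an amide-type nitrogen. Among the compounds with values here, no measured pair shows this change on its own, so the expected size of the step is uncertain; a modest shift toward a higher number, not clearly beyond the scatter, is expected, as a 1.7-fold higher number from compound 2 to compound 4 (0.22 log units; within the scatter). For compound 4 the estimate is 250 mg/kg, with a range from 120 mg/kg to 500 mg/kg.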

Compound 4, dose for half-maximal effect: 500 mg/kg
Beside the measured number, compound 4's estimate is 2.0-fold (0.30 log units) below it; the measured number falls inside the stated range.
By their numbers in this assay, from the lowest: compounds 2, 1, 3 and 4 (each within the scatter of the next, the first and the last beyond it).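

In this assay, vinyl in place of ethynyl on a saturated chain carbon bound to an amide-type nitrogen gives a 3.3-fold higher number from compound 2 to compound 4 (0.52 log units; beyond the scatter), so this first pair differing in one place shows that the position responds to this change. Both groups have the same heavy-atom count, and the step goes with a double bond replacing a triple bond. No measurement at hand explains the step. Still open, on these data alone, is where a propyl group or a longer chain such as butyl would fall at this position, and whether an amine on the chain would move the number.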